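Bromo in place of methylsulfanyl: notes on the series

The source may report more compounds than this note shows. Statements on the series, on what has been measured and on what is new or still open speak of the compounds shown alone.

Values in a physicochemical assay for lipophilicity; a lower number here means a more polar compound, a higher number a more lipophilic compound
compound 1 `CCSc1ccccc1C1=NC(c2ccccc2)CO1` gives 4.04
compound 2 `Clc1ccccc1C1=NC(c2ccccc2)CO1` gives 3.56
compound 3 `CSc1ccccc1C1=NC(c2ccccc2)CO1` gives 3.5
compound 4 `Brc1ccccc1C1=NC(c2ccccc2)CO1` is not yet measured

In this assay compound 3 at 3.5 cannot be told apart from compound 2 at 3.56 and the two share the low end of this small set. Compound 1 stands clear of both, with a number 0.54 log units lower from compound 1 to compound 3 (beyond the scatter) and a number 0.48 log units lower from compound 1 to compound 2 (beyond the scatter) as the two steps.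

The next change gives compound 4 and is bromo in place of methylsulfanyl on an aromatic carbon. Among the compounds with values here, no measured step in the set involves bromo, so the size must be judged from neighbouring exchanges at that place. The closest is chloro against methylsulfanyl, with a number 0.06 log units lower from compound 2 to compound 3 (within the scatter) as the measured step. The exchange of ethylsulfanyl for chloro, at a number 0.48 log units lower from compound 1 to compound 2 (beyond the scatter), shows that a change at this place can pass the scatter, and this argues for a range of some width. No step beyond the scatter is expected in this assay for the bromo exchange. The estimated step is a number 0.15 log units higher from compound 3 to compound 4 (within the scatter). For compound 4 the expected value is 3.65, with an estimated range from 3.35 to 3.95.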

Compound 4, partition coefficient: 3.69
For compound 4 the middle estimate is 0.04 log units below the measured one; measured number inside the range.
By their numbers in this assay, from the lowest: compounds 3, 2 and 4 (each within the scatter of the next); then compound 1.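

In this assay, within the data shown here, the bromo exchange gives (a number 0.19 log units higher from compound 3 to compound 4 (within the scatter)) and (a number 0.13 log units higher from compound 2 to compound 4 (within the scatter)) so that bromo, chloro and methylsulfanyl on this aromatic carbon form a single group of three that cannot be told apart, where the earlier compounds offered only one such pair. The separation of ethylsulfanyl from the rest of the set also holds against this third neighbour (a number 0.35 log units lower from compound 1 to compound 4 (beyond the scatter)) and so compound 1 remains the only one of the four that stands clear of the others at this place, even though methylsulfanyl and bromo differ in heavy atoms and in hydrogen-bond acceptors without a step beyond the scatter. No supporting measurement is available to explain this grouping.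

The four compounds leave open whether a charged group such as an amine or a carboxylic acid at this aromatic carbon would fall outside the group of three. They also leave open whether a longer chain on the sulfur, such as propylsulfanyl, would extend the step seen from methylsulfanyl to ethylsulfanyl, and whether any of these exchanges would behave the same way on a different core.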